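From thiophen-3-yl to 1-benzothiophen-2-yl: compound 4 outlook

A few compounds are considered here, and "the series" means these few. Any claim that something is new, unique, unknown or untested is made for them only; others in the source may bear on it.

Among the compounds with values here, in a functional assay on MCF7 cells (Homo sapiens) for antiproliferative activity, read by MTT assay (on this read-out higher numbers stand for weaker inhibition and lower numbers for stronger inhibition), compound 3 `COc1ccc([C@@H]2C(c3ccsc3)C(=O)N2c2cc(OC)c(OC)c(OC)c2)cc1` gives 60 nM, the lowest of the three numbers measured so far. Compound 1 `COc1ccc([C@@H]2C(c3ccoc3)C(=O)N2c2cc(OC)c(OC)c(OC)c2)cc1` gives 150 nM, and the step of a 2.5-fold lower number from compound 1 to compound 3 (0.40 log units; beyond the scatter) is modest. Compound 2 `COc1ccc([C@@H]2C(c3cc4ccccc4n3C)C(=O)N2c2cc(OC)c(OC)c(OC)c2)cc1` gives 6600 nM; the steps of a 44-fold higher number from compound 1 to compound 2 (1.64 log units; beyond the scatter) and a 110-fold lower number from compound 2 to compound 3 (2.04 log units; beyond the scatter) are both large. Compound 4 `COc1ccc([C@@H]2C(c3cc4ccccc4s3)C(=O)N2c2cc(OC)c(OC)c(OC)c2)cc1` differs from compound 3 by 1-benzothiophen-2-yl in place of thiophen-3-yl on a saturated ring carbon. The measured step that bears on this is a 44-fold higher number from compound 1 to compound 2 (1.64 log units; beyond the scatter), where a group holding one six-membered aromatic ring of carbon only replaced a five-membered ring with 1 hetero atom on the same saturated ring carbon. A large upward step a 25-fold higher number from compound 3 to compound 4 (1.40 log units; beyond the scatter) is therefore expected for compound 4, with no measured case to argue otherwise. Compound 4 is estimated at 1500 nM, with a range from 300 nM to 8000 nM.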

Compound 4, half-maximal inhibitory concentration: 850 nM
Estimate against measurement, compound 4: 1.8-fold (0.25 log units) above, within the range that was stated.
By their numbers in this assay, from the lowest: compound 3; then compound 1; then compound 4; then compound 2.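

Going from thiophen-3-yl to 1-benzothiophen-2-yl on this saturated ring carbon gives a 14-fold higher number from compound 3 to compound 4 (1.15 log units; beyond the scatter), so the loss seen with 1-methyl-1H-indol-2-yl is not unique to that group. The 1-benzothiophen-2-yl group also reads weaker than furan-3-yl, with a 5.7-fold higher number from compound 1 to compound 4 (0.75 log units; beyond the scatter), yet it reads stronger than the indole group, with a 7.8-fold lower number from compound 2 to compound 4 (0.89 log units; beyond the scatter), so the identity of the two-ring group matters.

No measured property of these compounds bears on the cause of these steps. From the compounds shown here alone, how thiophen-2-yl would read here remains open, and it would separate the added six-membered ring from the change of attachment.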